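Working notes: replacing the terminal ring of compound 1

This account rests on a few compounds, and the source may have more. Where it says the series, first, only, none or still open, it means among the compounds named here.

Measured so far in an assay on isolated protein for inhibition of Maltase-glucoamylase (Homo sapiens), with a stated time of 15 min; on this read-out higher numbers stand for weaker inhibition and lower numbers for stronger inhibition:
- compound 1 `O=C(N/N=C/c1cccs1)c1ccc(-c2nc3ccccc3s2)cc1`: 8480 nM
- compound 2 `O=C(N/N=C/c1cccc(O)c1O)c1ccc(-c2nc3ccccc3s2)cc1`: 11200 nM
- compound 3 `COC(=O)c1ccc(/C=N/NC(=O)c2ccc(-c3nc4ccccc4s3)cc2)cc1`: "not active" (no number reported) (no number reported)

Compound 1 holds the lowest of the two numbers in this assay; compound 2 sits nearest, and the step of a 1.3-fold higher number from compound 1 to compound 2 (0.12 log units; within the scatter) is within the scatter, so the two cannot be ordered. Compound 3 is reported without a number in this assay.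

The next compound, compound 4 `O=C(N/N=C/c1ccc([N+](=O)[O-])cc1)c1ccc(-c2nc3ccccc3s2)cc1`, differs from compound 1 as follows: 4-nitrophenyl in place of thiophen-2-yl on a carbon with a double bond to nitrogen. Going by the values given here, the only measured step that bears on this change is the ring swap from compound 1 to compound 2, which stayed within the scatter; compound 3, another six-membered carbon ring carrying a substituent in the same place, gave no number at all. The evidence therefore points to a step of no clear direction, with a real chance that compound 4 also returns no number. Compound 4 is expected at 12000 nM (range 5000 nM to 40000 nM), a step of a 1.4-fold higher number from compound 1 to compound 4 (0.15 log units; within the scatter) that is estimated to stay near compound 1.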

Compound 4, half-maximal inhibitory concentration: 26400 nM
The estimate for compound 4 lay 2.2-fold (0.34 log units) below the measured number; low and high end bracket the measured number.
By their numbers in this assay, from the lowest: compounds 1 and 2 (each within the scatter of the next); then compound 4.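

In this assay, going by these compounds alone, 4-nitrophenyl in place of thiophen-2-yl on a carbon with a double bond to nitrogen gives a 3.1-fold higher number from compound 1 to compound 4 (0.49 log units; beyond the scatter), the first step at this place to go beyond the scatter, so a change of terminal ring can weaken inhibition here, if only modestly. 4-Nitrophenyl in place of 2,3-dihydroxyphenyl gives a 2.4-fold higher number from compound 2 to compound 4 (0.37 log units; beyond the scatter), a modest step in the same direction, which separates compound 4 from both compounds that carry a number. No measured data are available to explain this loss of inhibition.

Compound 3 has no number, so steps to it cannot be read. On these data alone, it remains open whether phenyl, 4-aminophenyl or 4-carboxyphenyl at this place would give numbers closer to compound 1 or to compound 4, and so whether the step follows the six-membered ring or the nitro group.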